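From nitro to methoxy on a weak inhibitor

The source may hold more compounds than are shown below. What is called first, only, known or untested is meant among the compounds shown, and "the series" means these compounds.

For the measured compounds named here, in a physicochemical assay, read by spectrophotometry, with a stated time of 30 min (a higher number here means a weaker inhibitor, a lower number a stronger inhibitor), compound 1 (`O=C(CCc1nc2ccccc2c(=O)[nH]1)N/N=C/c1ccc([N+](=O)[O-])cc1`) gives 328000000 nM, which puts it at the high, weak end of the numbers so far. It shares that place with compound 3 (`O=C(CCCc1nc2ccccc2c(=O)[nH]1)N/N=C/c1ccc([N+](=O)[O-])cc1`), which gives 316000000 nM, and the two cannot be told apart within the scatter. Compound 2 (`COc1cc(/C=N/NC(=O)CCc2nc3ccccc3c(=O)[nH]2)cc(OC)c1OC`) gives 85000000 nM, a lower number and beyond the scatter from compound 1.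

Compound 4 (`COc1ccc(/C=N/NC(=O)CCc2nc3ccccc3c(=O)[nH]2)cc1`) keeps the rest of compound 1 and swaps one group: methoxy in place of nitro on an aromatic carbon. Methoxy stands in place of nitro on an aromatic carbon, turning 4-nitrophenyl into 4-methoxyphenyl. Going by the values given here, no measured pair shows this change alone, so its size is uncertain. Compound 2 also carries methoxy groups and no nitro, and its 85000000 nM points to a moderate step towards a lower number in this assay, though perhaps not one clear of the scatter. The expected change is a 2.1-fold lower number from compound 1 to compound 4 (0.31 log units; beyond the scatter). For compound 4 the estimated value is 160000000 nM, within an expected range of 60000000 nM to 400000000 nM.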

Compound 4, half-maximal inhibitory concentration: 214000000 nM
Compound 4: the middle estimate sits 1.3-fold (0.13 log units) below what was measured; low and high end bracket the measured number.
By their numbers in this assay, from the lowest: compound 2; then compounds 4, 3 and 1 (each within the scatter of the next).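

Taken alone, methoxy in place of nitro gives a 1.5-fold lower number from compound 1 to compound 4 (0.19 log units; within the scatter) in this assay, the first direct reading of this change. On this aromatic carbon, para to a large group, the swap therefore produces no change that can be told apart from the scatter, even though the two groups differ in their atoms and in their counts of hydrogen-bond acceptors. No measurement at hand explains this result.

Going by these compounds, it remains open whether an amine or a carboxylic acid on this same aromatic carbon would shift the number beyond the scatter. The compounds shown also leave open whether methoxy in place of nitro would read the same way on the longer chain of compound 3.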